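The source may hold more compounds than are shown below. What is called first, only, known or untested is meant among the compounds shown, and "the series" means these compounds.

Measured in an ADME assay on MT4 cells (Homo sapiens) for cytotoxicity, read by MTT assay, with a stated time of 5 days; a higher number here means that more compound is tolerated, a lower number that less compound is tolerated:
- compound 1 `C=CCNc1cc(Oc2c(C)cc(/C=C/C#N)cc2C)nc(Nc2ccc(C#N)cc2)n1`: 3050 nM
- compound 2 `Cc1cc(/C=C/C#N)cc(C)c1Oc1cc(Nc2ccc(C#N)cc2)nc(NC2CC2)c1`: 24800 nM
- compound 3 `COCCNc1cc(Oc2c(C)cc(/C=C/C#N)cc2C)cc(Nc2ccc(C#N)cc2)n1`: 58200 nM

Compound 1 has the lowest number of the three, so the least compound is tolerated. Compound 4 `Cc1cc(/C=C/C#N)cc(C)c1Oc1cc(NCCN2CCNCC2)nc(Nc2ccc(C#N)cc2)n1` is not yet measured. It differs from compound 1 as follows: (piperazin-1-yl)methyl in place of vinyl on a saturated chain carbon bound to a nitrogen on an aromatic ring. Among the compounds with values here, no measured compound carries this piperazine group. The nearest evidence is a single step on a nitrogen substituent, a 2.3-fold higher number from compound 2 to compound 3 (0.37 log units; beyond the scatter), a modest change with 2-methoxyethyl in place of cyclopropyl. It moved upward, and compound 2 and compound 3 both sit well above compound 1, so a modest rise is expected, though this support is thin. The expected change is a 3.0-fold higher number from compound 1 to compound 4 (0.47 log units; beyond the scatter). Compound 4 is estimated at 9000 nM, with an expected range of 2500 nM to 32000 nM.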

Compound 4, half-maximal cytotoxic concentration: 3650 nM
Beside the measured number, compound 4's estimate is 2.5-fold (0.39 log units) above it; low and high end bracket the measured number.
By their numbers in this assay, from the lowest: compounds 1 and 4 (each within the scatter of the next); then compound 2; then compound 3.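

In this assay, 2-(piperazin-1-yl)ethyl in place of allyl on the nitrogen gives a 1.2-fold higher number from compound 1 to compound 4 (0.08 log units; within the scatter). At this position, then, a larger group with a six-membered non-aromatic ring and a hydrogen-bond donor, neither of which allyl has, gives a number that cannot be told apart from that of compound 1. Nothing measured here offers a reason for this result. Open, as far as these compounds go, is whether a morpholine ring in place of the piperazine, or a simple amine on the same chain, would also stay this close to compound 1. From the compounds shown here alone, a longer chain carrying the piperazine is equally open.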